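The source may report more compounds than this note shows. Statements on the series, on what has been measured and on what is new or still open speak of the compounds shown alone.

Compound 1 `COc1ccccc1/C=C/C(=O)OC/C=C/c1cc(OC)c(OC)cc1OC` gives 101 umol/kg
Compound 2 `COc1cc(OC)c(OC)cc1/C=C/COC(=O)/C=C/c1c(OC)ccc(OC)c1OC` gives 120 umol/kg
Compound 3 `COc1cc(OC)c(OC)cc1/C=C/COC(=O)/C=C/c1cc(OC)c(OC)c(OC)c1OC` gives 65.1 umol/kg

These three values come from a functional assay on the whole organism (strain Kunming) with Mus musculus as the target, with a stated time of 0.5 h (on this read-out higher numbers stand for an effect only at larger amounts of compound and lower numbers for an effect already at smaller amounts), and lie close together. Compound 1 stands within the scatter of both compound 2 and compound 3, so it holds no distinct place among them. Compound 4 `COc1cc(OC)c(OC)cc1/C=C/COC(=O)/C=C/c1ccccc1Cl` has not yet been measured in this assay and keeps the core of compound 1. It carries chloro in place of methoxy on an aromatic carbon, ortho to a large group, which reads as 2-methoxyphenyl to 2-chlorophenyl (chloro in place of methoxy on an aromatic carbon). Among the compounds with values here, no measured compound carries chloro, and no measured pair differs in one place only, so the data give no direct guide. The nearest hint is that compound 2 at 120 umol/kg and compound 3 at 65.1 umol/kg stay within the scatter of compound 1 although their methoxy groups differ from its own. No shift beyond the scatter is therefore expected in this assay in either direction. The expected move is a 1.1-fold lower number from compound 1 to compound 4 (0.03 log units; within the scatter) and is estimated to stay within the scatter. For compound 4 the estimated value is 95 umol/kg with 45 umol/kg to 210 umol/kg as its expected range.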

Compound 4, dose for half-maximal effect: 151 umol/kg
Compound 4: middle estimate off by 1.6-fold (0.20 log units), on the low side; the range from low to high includes it.
By their numbers in this assay, from the lowest: compounds 3, 1, 2 and 4 (each within the scatter of the next, the first and the last beyond it).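

In this assay, within the data shown here, the change from 2-methoxyphenyl to 2-chlorophenyl gives the first readable step at this position, on an aromatic carbon ortho to a large group. The step, a 1.5-fold higher number from compound 1 to compound 4 (0.17 log units; within the scatter), shows that this single exchange of methoxy for chloro leaves the read-out within the usual scatter. On this one pair, then, the methoxy group at this place is not needed for an effect at doses of this size, and no measured finding accounts for the outcome.

As far as these compounds go, what a hydroxyl group, an amine or a carboxylic acid would do at this same place remains open. From the compounds shown here alone, it is also open whether chloro would give a similar result on the other side of the ester, in the core of compound 1.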